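Carbonyl substituent swap on compound 3

The source may report more compounds than this note shows. Statements on the series, on what has been measured and on what is new or still open speak of the compounds shown alone.

Values in a functional assay on U-87MG ATCC cells (Homo sapiens) for antiproliferative activity; on this read-out higher numbers stand for weaker inhibition and lower numbers for stronger inhibition:
- compound 1 `Cc1c2c(n3c1CCCN(C)[C@@H](C)[C@H](C)Nc1cc-3ccc1C(N)=O)CC(C)(C)CC2=O`: 133 nM
- compound 2 `CC(=O)N1CCCc2c(C)c3c(n2-c2ccc(C(N)=O)c(c2)N[C@@H](C)[C@@H]1C)CC(C)(C)CC3=O`: 29 nM
- compound 3 `COCCC(=O)N1CCc2c(C)c3c(n2-c2ccc(C(N)=O)c(c2)N[C@@H](C)[C@H](C)C1)CC(C)(C)CC3=O`: 54 nM

Compound 3 lies within the scatter of compound 2 and beyond the scatter from compound 1, on the lower-number side. The next compound is compound 4 `Cc1c2c(n3c1CCN(C(=O)[C@H](C)O)C[C@@H](C)[C@H](C)Nc1cc-3ccc1C(N)=O)CC(C)(C)CC2=O`, with the change (1-hydroxyethyl in place of 2-methoxyethyl on a carbonyl carbon). For the measured compounds named here, the only measured step, a 4.6-fold lower number from compound 1 to compound 2 (0.66 log units; beyond the scatter), is acetyl in place of methyl on an amine nitrogen in a ring, so it bears only indirectly. Going by the values given here, no step on this carbonyl substituent has been measured, so compound 3 at 54 nM serves as the base, and no shift beyond the scatter is expected in this assay. The expected step is a 1.1-fold lower number from compound 3 to compound 4 (0.05 log units; within the scatter). For compound 4 the estimate is 48 nM, with an expected range of 18 nM to 125 nM.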

Compound 4, half-maximal inhibitory concentration: 88 nM
The estimate for compound 4 lay 1.8-fold (0.26 log units) below the measured number; the range from low to high includes it.
By their numbers in this assay, from the lowest: compounds 2, 3, 4 and 1 (each within the scatter of the next, the first and the last beyond it).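

In this assay, the first step measured on this carbonyl substituent, a 1.6-fold higher number from compound 3 to compound 4 (0.21 log units; within the scatter), does not separate 1-hydroxyethyl from 2-methoxyethyl on a carbonyl carbon. In this one pair, the position accepts a hydrogen-bond donor and a defined stereocentre without a shift beyond the scatter. No measured evidence bears on this result. Still open, from the compounds shown here alone, is whether an amine, a carboxylic acid or a longer chain on this carbonyl carbon would move the number beyond the scatter. Going by these compounds, the opposite stereocentre of the 1-hydroxyethyl group also remains open.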